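A Single Side-Group Swap, Read Against Two Measurements

The compounds below may be only part of what the source reports. "The series", "measured", "known", "first", "only" and "open" are said of these compounds alone.

In a functional assay on the whole organism with Mus musculus as the target (on this read-out lower numbers stand for smaller maximal responses and higher numbers for larger maximal responses), two compounds have been measured so far. Compound 1 `Nc1nc(O)c2c(n1)n(C1OC(CO)[C@@H](O)[C@H]1O)c(=O)n2C/C=C/c1ccccc1` gives 5%, the lowest of the two numbers. Compound 2 `C=CCn1c(=S)n(C2OC(COC(C)=O)[C@H]3OC(C)(C)O[C@@H]23)c2nc(N)nc(O)c21` gives 20%, a number that lies beyond the scatter above compound 1. Going by the values given here, compound 2 differs from compound 1 in several places at once, so the two values show only that compound 2 reaches the larger response, not which change is responsible.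

Compound 3 `Nc1nc(O)c2c(n1)n(C1OC(CO)[C@@H](O)[C@H]1O)c(=O)n2Cc1ccc([N+](=O)[O-])cc1` has not yet been measured. It differs from compound 1 in one place: 4-nitrophenyl in place of 2-phenylethenyl on a saturated chain carbon bound to an aromatic nitrogen. Among the compounds with values here, no step of this kind has been measured, so its size in this assay is open; a small shift in either direction, or none beyond the scatter, is expected. Compound 3 is expected to give 10%, within a range from 0% to 30%. That estimate means an expected step of a number 5 percentage points higher from compound 1 to compound 3 (within the scatter), staying within the scatter.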

Compound 3, largest response reached (reported as maximal response), in percent of the reference or control that the assay uses: 16%
Beside the measured number, compound 3's estimate is 6 percentage points below it; the measured number falls inside the stated range.
By their numbers in this assay, from the lowest: compound 1; then compounds 3 and 2 (each within the scatter of the next).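

At this place, on a saturated chain carbon bound to an aromatic nitrogen, the side group matters in this assay: 4-nitrophenyl in place of 2-phenylethenyl gives a number 11 percentage points higher from compound 1 to compound 3 (beyond the scatter) and so counts as a modest step. The earlier pair differed in several places at once, whereas this change sits in one place and the shared core stays the same, so the difference can be tied to this side group. Nothing measured here explains why the number moves.

The swap replaces the whole 3-phenylprop-2-en-1-yl group with 4-nitrobenzyl, so the compounds shown cannot separate the effect of adding the nitro group from the effect of changing the link to the ring. A plain benzyl group would pull those two parts apart, and a 4-aminobenzyl group would show whether the nitro group itself can be exchanged at this place.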